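This account rests on a few compounds, and the source may have more. Where it says the series, first, only, none or still open, it means among the compounds named here.

Measured so far:
compound 1, `COc1ccc(OC)c(/C=C/c2nnc(Nc3ccc(Cl)cc3)o2)c1`: 53100 nM
compound 2, `COc1ccc(OC)c(/C=C/C(=O)N/N=C/c2ccc(Cl)cc2)c1`: > 100000 nM

Both compounds were run in a functional assay on MDA-MB-231 cells (Homo sapiens) for antiproliferative activity, read by sulforhodamine B assay, with a stated time of 48 h; a lower number here means a stronger inhibitor of growth, a higher number a weaker inhibitor of growth. Compound 1 gives 53100 nM. For compound 2 only a limit is recorded, > 100000 nM, and this is not a number. Compound 2 therefore stands at the limit of > 100000 nM in this assay, at which 1 of the 2 values shown sits. Going by the values given here, no step between the two measured compounds is counted, since they differ in more than one place; their values show only that compound 1 has a number while compound 2 has a limit.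

Compound 3, `COc1ccc(OC)c(/C=C/C(=O)N/N=C/c2ccccc2)c1`, is not yet measured. It differs from compound 2 as follows: hydrogen in place of chloro on an aromatic carbon. Hydrogen replaces chloro on an aromatic carbon of the six-membered aromatic ring of carbon only, para to a large group. Among the compounds with values here, no comparable step is recorded, so no size can be drawn from measured pairs. The step from compound 2 to compound 3 is expected to stay within the scatter, with no clear direction, and compound 3 is expected most likely to come back again as a limit rather than a number. The estimate for compound 3 is 150000 nM, with a range from 50000 nM to 500000 nM. The expected step is a step that the limit leaves unreadable from compound 2 to compound 3.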

Compound 3, concentration for total growth inhibition: > 100000 nM
Compound 3: no number, only a limit (the forecaster's own chance of this, stated with the estimate: 80%); the middle value is on the limit's open side.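

Compound 3 in this assay returns a limit, > 100000 nM, not a number. Compound 2 is likewise a limit, > 100000 nM, and the step between these two compounds cannot be read. The compounds shown leave open whether 4-chlorophenyl and phenyl differ at all in growth inhibition, with neither compound 2 nor compound 3 carrying a number.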